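The source may hold more compounds than are shown below. What is called first, only, known or untested is meant among the compounds shown, and "the series" means these compounds.

Measured compounds:
Compound 1 `C=CC(=O)N1CC[C@H](N2C(=O)N(c3ccccc3)Cc3cnc(Nc4ccc(N5CCN(C)CC5)cc4OC)nc32)C1` gives 962 ng.h/mL in an ADME assay on the whole organism (plasma, strain Sprague-Dawley) for pharmacokinetics, with Rattus norvegicus as the target, read by LC-MS, at a dose of 5 mg/kg by the intravenous route; on this read-out higher numbers stand for higher exposure at the dose given and lower numbers for lower exposure.
Compound 2 `C=CC(=O)N1CC[C@H](N2C(=O)N(c3ccccc3)Cc3cnc(Nc4ccc(N5CCN(C)CC5)c(OC)c4)nc32)C1` gives 949 ng.h/mL in this assay.
Compound 3 `C=CC(=O)N1CC[C@H](N2C(=O)N(c3ccccc3)Cc3cnc(Nc4ccc(N5CCN(C)CC5)c(C)c4)nc32)C1` gives 1640 ng.h/mL in this assay.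

Compound 1 stands second highest of these three numbers, yet it lies within the scatter of compound 2 and within the scatter of compound 3 as well, so the three measured values cannot be told apart with confidence. For the measured compounds named here, the only step between neighbours that differ in one place, a 1.7-fold higher number from compound 2 to compound 3 (0.24 log units; within the scatter), also lies within the scatter.

Compound 4 `C=CC(=O)N1CC[C@H](N2C(=O)N(Cc3ccccc3)Cc3cnc(Nc4ccc(N5CCN(C)CC5)cc4OC)nc32)C1` differs from compound 1 by benzyl in place of phenyl on an amide-type nitrogen in a ring. Going by the values given here, no measured step touches this kind of change: the one step available concerns a group on an aromatic carbon, not the ring nitrogen that carries the phenyl or benzyl group. The three measured values lie close together and none of their steps goes beyond the scatter, so for compound 4 the expected step is a 1.1-fold lower number from compound 1 to compound 4 (0.05 log units; within the scatter), no larger than the scatter. The estimate for compound 4 in this assay is 850 ng.h/mL, with a range from 350 ng.h/mL to 2000 ng.h/mL.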

Compound 4, area under the concentration-time curve: 359 ng.h/mL
The estimate for compound 4 lay 2.4-fold (0.37 log units) above the measured number, and the stated range covers the measured number.
By their numbers in this assay, from the lowest: compound 4; then compounds 2, 1 and 3 (each within the scatter of the next).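

In this assay, for the compounds shown here, benzyl in place of phenyl on the amide-type nitrogen in a ring gives a 2.7-fold lower number from compound 1 to compound 4 (0.43 log units; beyond the scatter) and is the first step in this set to lie beyond the scatter. The earlier step concerned a group on an aromatic carbon and stayed within the scatter, whereas this nitrogen is a place where a change of group can visibly alter exposure at the dose given, although the drop is modest and rests on this single pair. Nothing measured here gives a reason for the drop.

Going by these compounds, it remains open whether the same swap would lower exposure in the same way on the cores of compound 2 and compound 3, which carry their groups elsewhere on the aromatic ring. Also open, on these data alone, is how a simple methyl, a saturated cyclohexyl or a longer phenylethyl chain on this nitrogen would compare with phenyl and benzyl.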